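This account rests on a few compounds, and the source may have more. Where it says the series, first, only, none or still open, it means among the compounds named here.

Compound 1 `COc1ccc(C(=O)Nc2nc(-c3ccccc3)cn3cc(-c4ccccc4)nc23)cc1` gives 25 nM in an assay on cells for displacement of a labelled ligand from transmembrane domain-containing protein TMIGD3 (Homo sapiens), read by scintillation counting, with a stated time of 120 min; on this read-out higher numbers stand for weaker inhibition and lower numbers for stronger inhibition.
Compound 2 `Cc1ccc(C(=O)Nc2nc(-c3ccccc3)cn3cc(-c4ccccc4)nc23)cc1` gives 223 nM in this assay.
Compound 3 `O=C(Nc1nc(-c2ccccc2)cn2cc(-c3ccccc3)nc12)c1ccc(Cl)cc1` gives 156 nM in this assay.

Compound 3 stands second highest of these three numbers. Its nearest neighbour is compound 2, reached by a 1.4-fold lower number from compound 2 to compound 3 (0.16 log units; within the scatter), so the two cannot be told apart on these data. The gap to compound 1 is wider: a 6.2-fold higher number from compound 1 to compound 3 (0.80 log units; beyond the scatter), a step beyond the scatter, and likewise an 8.9-fold higher number from compound 1 to compound 2 (0.95 log units; beyond the scatter).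

The new compound, compound 4 `O=C(Nc1nc(-c2ccccc2)cn2cc(-c3ccccc3)nc12)c1ccc(F)cc1`, differs from compound 3 in one place: fluoro in place of chloro on an aromatic carbon. Among the measured compounds shown here, no measured step swaps one halogen for another. The steps that come closest are those that exchange the group at this same place: a 1.4-fold lower number from compound 2 to compound 3 (0.16 log units; within the scatter) stayed within the scatter, while a 6.2-fold higher number from compound 1 to compound 3 (0.80 log units; beyond the scatter) was a modest step beyond it. Fluoro is untested in this series, so the expectation rests on the observation that methyl and chloro gave numbers close to each other there, while only methoxy stood apart. The expected outcome for compound 4 is therefore a step of a 1.2-fold higher number from compound 3 to compound 4 (0.09 log units; within the scatter) in this assay, with a fair chance that the number stays within the usual scatter. On that basis compound 4 is estimated at 190 nM, with a range from 60 nM to 600 nM.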

Compound 4, inhibition constant: 38 nM
Compound 4: the middle estimate sits 5.0-fold (0.70 log units) above what was measured, outside the stated range (below it).
By their numbers in this assay, from the lowest: compounds 1 and 4 (each within the scatter of the next); then compounds 3 and 2 (each within the scatter of the next).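

Among the compounds shown here, at this place on the ring, para to a large group, the earlier compounds left methoxy standing apart, with methyl and chloro close together, but fluoro changes that picture: in this assay, fluoro in place of chloro gives a clear change (a 4.1-fold lower number from compound 3 to compound 4 (0.61 log units; beyond the scatter)), and fluoro in place of methyl gives a similar one (a 5.9-fold lower number from compound 2 to compound 4 (0.77 log units; beyond the scatter)). Fluoro and methoxy, by contrast, cannot be told apart (a 1.5-fold higher number from compound 1 to compound 4 (0.18 log units; within the scatter)), so among these four compounds, methoxy is no longer alone in giving a low number, and the two halogens do not behave alike at this position. Nothing measured here explains why fluoro and chloro part ways.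

The compounds shown leave open where other groups at this place, such as a hydroxyl, an amine, a nitrile or a longer chain like ethoxy, would fall relative to these four. They also leave open whether fluoro would give a similar result at another place on this ring, or whether its match with methoxy holds in other assays.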